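The source may hold more compounds than are shown below. What is called first, only, known or untested is meant among the compounds shown, and "the series" means these compounds.

Measured in an ADME assay on BHK-21 cells (Mesocricetus auratus) for cytotoxicity, read by MTT assay, with a stated time of 72 h; a higher number here means that more compound is tolerated, a lower number that less compound is tolerated:
- compound 1 `NS(=O)(=O)c1ccc(N2N=C(c3ccc(OCc4ccccc4)cc3)CC2c2ccc(F)cc2)cc1`: 60000 nM
- compound 2 `NS(=O)(=O)c1ccc(N2N=C(c3ccc(Oc4ccccc4)cc3)CC2c2cccc(F)c2)cc1`: 10000 nM
- compound 3 `NS(=O)(=O)c1ccc(N2N=C(c3ccc(OCc4ccccc4)cc3)CC2c2ccccc2F)cc1`: 90000 nM

Compound 3, at 90000 nM, stands level with compound 1 within the scatter, while compound 2 has a clearly lower number. The next compound, compound 4 `NS(=O)(=O)c1ccc(N2N=C(c3ccc(OCc4ccccc4)cc3)CC2c2cccc(F)c2)cc1`, differs from compound 3 in one place, with 3-fluorophenyl in place of 2-fluorophenyl on a saturated ring carbon. One measured step is of the same kind: a 1.5-fold higher number from compound 1 to compound 3 (0.18 log units; within the scatter), where 2-fluorophenyl replaces 4-fluorophenyl at that same carbon. Within the data shown here, compound 2 also carries 3-fluorophenyl and gives 10000 nM, but it differs from compound 4 elsewhere in the structure, and no measured step isolates that change. The fluorine shift already measured made no difference beyond the scatter, so none is expected here in this assay. The expected change is a 1.3-fold lower number from compound 3 to compound 4 (0.11 log units; within the scatter). For compound 4 the estimate is 70000 nM, with an expected range from 30000 nM to 130000 nM.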

Compound 4, half-maximal cytotoxic concentration: 9000 nM
Beside the measured number, compound 4's estimate is 7.8-fold (0.89 log units) above it; measured number below the stated range.
By their numbers in this assay, from the lowest: compounds 4 and 2 (each within the scatter of the next); then compounds 1 and 3 (each within the scatter of the next).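

In this assay, moving the fluorine on this phenyl group at the saturated ring carbon does matter, contrary to what the earlier step suggested: 3-fluorophenyl in place of 2-fluorophenyl gives a 10-fold lower number from compound 3 to compound 4 (1.00 log units; beyond the scatter), and 3-fluorophenyl in place of 4-fluorophenyl gives a 6.7-fold lower number from compound 1 to compound 4 (0.82 log units; beyond the scatter). With 3-fluorophenyl held constant, benzyl in place of phenyl on the oxygen gives a 1.1-fold lower number from compound 2 to compound 4 (0.05 log units; within the scatter), so in this pair that exchange leaves the number unchanged within the scatter. Nothing available here explains why the 3-fluorophenyl group stands apart.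

From the compounds shown here alone, it remains open whether this lower number is tied to fluorine or would also appear with 3-chlorophenyl or 3-methoxyphenyl at this carbon. An unsubstituted phenyl group would show how each fluorophenyl compound compares with having no fluorine there.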